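The compounds below may be only part of what the source reports. "The series", "measured", "known", "first", "only" and "open" are said of these compounds alone.

Measured in an assay on membranes from HeLa cells for displacement of a labelled ligand from adenosine receptor A3 (Homo sapiens), read by scintillation counting, with a stated time of 180 min, tested at 1 uM; a higher number here means more inhibition at the concentration tested (going by the name of the read-out), a lower number less inhibition:

compound 1 `CC1=C(C(=O)OC(C)(C)C)C(c2ccsc2)NC(=O)N1` — 1%
compound 2 `CCCC(=O)C1=C(C)NC(=O)NC1c1ccsc1` — 1%
compound 3 `CCNC(=O)C1=C(C)NC(=O)NC1c1ccco1` — 3%

Compound 3 has the highest of the three numbers, but the gap to compound 1 and the gap to compound 2 are both within the scatter, so no order among the three can be read from these values; all three sit at the bottom of the read-out in this assay.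

The unmeasured compound 4 `CCNC(=O)C1=C(C)NC(=O)NC1c1ccsc1` differs from compound 3 in one place: thiophen-3-yl in place of furan-2-yl on a saturated ring carbon.

Within the data shown here, only one measured step exists, no change at the digits printed from compound 1 to compound 2 (within the scatter), and it concerns the group on the carbonyl carbon, not the aromatic ring on the saturated ring carbon. Among the measured compounds shown here, no measured pair isolates the furan-2-yl to thiophen-3-yl exchange. What can be said is that compound 1 and compound 2, both bearing thiophen-3-yl, and compound 3, bearing furan-2-yl, all give numbers within the scatter of one another in this assay. On that basis the expected step is a number 1 percentage points lower from compound 3 to compound 4 (within the scatter), that is, none beyond the scatter.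

Compound 4 is therefore estimated at 2% in this assay, with a range from 0% to 8%.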

Compound 4, a percentage reported as inhibition, at one concentration (the size of the read-out at that concentration, not a potency): 1%
Compound 4: the middle estimate sits 1 percentage points above what was measured; the measured number falls inside the stated range.
By their numbers in this assay, from the lowest: compounds 1, 2, 4 and 3 (each within the scatter of the next).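

In this assay the aromatic ring on the saturated ring carbon is now exchanged with the ethylcarbamoyl group held fixed, and thiophen-3-yl in place of furan-2-yl gives a number 2 percentage points lower from compound 3 to compound 4 (within the scatter); at this position, swapping one five-membered aromatic ring with a single hetero atom for another therefore leaves the read-out unmoved beyond the scatter. With thiophen-3-yl held fixed, ethylamino on the carbonyl carbon joins propyl and tert-butoxy, with no change at the digits printed from compound 2 to compound 4 (within the scatter) and no change at the digits printed from compound 1 to compound 4 (within the scatter), so none of these three groups separates from the others at this concentration. Nothing available bears on why the numbers stay this low.

All values lie at the bottom of the read-out, so these flat steps do not show whether the same exchange would matter in a compound with a clearly higher number. From the compounds shown here alone, whether a phenyl ring on the saturated ring carbon, or a benzylamino group or a carboxylic acid on the carbonyl carbon, would lift the number beyond the scatter remains open.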